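Compound 3 and the Amide Nitrogen Substituent

The source may report more compounds than this note shows. Statements on the series, on what has been measured and on what is new or still open speak of the compounds shown alone.

Measured so far in a functional assay on NCI-H146 cells (Homo sapiens) for inhibition, read by WST assay, with a stated time of 4 days (a higher number here means a weaker inhibitor, a lower number a stronger inhibitor), for two compounds:
Compound 1 `CNC(=O)c1c(-c2cccc(N3CCN(c4ccc(NS(=O)(=O)c5ccc(N[C@H](CCN(C)C)CSc6ccccc6)c([N+](=O)[O-])c5)cc4)CC3)c2)c(-c2ccc(Cl)cc2)n(C)c1C` gives 36 nM in this series
Compound 2 `Cc1c(C(=O)N[C@H]2C[C@@](C)(O)C2)c(-c2cccc(N3CCN(c4ccc(NS(=O)(=O)c5ccc(N[C@H](CCN(C)C)CSc6ccccc6)c([N+](=O)[O-])c5)cc4)CC3)c2)c(-c2ccc(Cl)cc2)n1C` gives 12 nM in this series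

Of these two, compound 2 has the lower number, at 12 nM in this assay and so is the stronger inhibitor of the pair. Compound 3 `Cc1c(C(=O)NS(C)(=O)=O)c(-c2cccc(N3CCN(c4ccc(NS(=O)(=O)c5ccc(N[C@H](CCN(C)C)CSc6ccccc6)c([N+](=O)[O-])c5)cc4)CC3)c2)c(-c2ccc(Cl)cc2)n1C` has not yet been measured. It keeps the core of compound 2 and differs at one place: methylsulfonyl in place of 3-hydroxy-3-methylcyclobutyl on an amide-type nitrogen that is, methylsulfonyl in place of 3-hydroxy-3-methylcyclobutyl on an amide-type nitrogen.

Within the data shown here, only one measured step touches this nitrogen, the modest 3.0-fold lower number from compound 1 to compound 2 (0.48 log units; beyond the scatter) that goes with 3-hydroxy-3-methylcyclobutyl in place of methyl. Among the measured compounds shown here, no measured compound carries methylsulfonyl, so that step is a rough guide only. With the 3-hydroxy-3-methylcyclobutyl group gone, a loss of similar size seems the likeliest outcome. The expected step runs a 2.9-fold higher number from compound 2 to compound 3 (0.46 log units; beyond the scatter) and is estimated to be modest and toward a higher number. Compound 3 is therefore expected at 35 nM in this assay with an estimated range from 10 nM to 120 nM around that figure.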

Compound 3, half-maximal inhibitory concentration: 38 nM
Compound 3: the middle estimate sits 1.1-fold (0.04 log units) below what was measured; low and high end bracket the measured number.
By their numbers in this assay, from the lowest: compound 2; then compounds 1 and 3 (each within the scatter of the next).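

In this assay the methylsulfonyl group on this amide-type nitrogen does not hold the level reached with the 3-hydroxy-3-methylcyclobutyl group, the change giving a 3.2-fold higher number from compound 2 to compound 3 (0.50 log units; beyond the scatter) as its step. Set against the methyl group, the same methylsulfonyl group gives a 1.1-fold higher number from compound 1 to compound 3 (0.02 log units; within the scatter) so these two substituents cannot be told apart in this assay, even though methylsulfonyl brings in a sulfur and two oxygens. Of the three substituents now seen on this nitrogen, only the 3-hydroxy-3-methylcyclobutyl group of compound 2 stands apart, and no measured property of these groups is available to account for that.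

The compounds shown leave open whether the lower number of compound 2 goes with the four-membered ring, with its hydroxyl or with the defined stereocentres, and a plain cyclobutyl group or a 2-hydroxyethyl chain on this nitrogen would begin to separate these. They also leave open whether a larger sulfonyl group, such as phenylsulfonyl, would stay level with methylsulfonyl or move away from it.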